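A few compounds are considered here, and "the series" means these few. Any claim that something is new, unique, unknown or untested is made for them only; others in the source may bear on it.

Of the compounds shown here, three have been measured in a functional assay on MCF7 cells (Homo sapiens) for inhibition, read by sulforhodamine B assay, with a stated time of 48 h; on this read-out higher numbers stand for weaker inhibition of growth and lower numbers for stronger inhibition of growth.
Compound 1, `CC1=CC[C@H](C(C)(C)NC(=S)NN)CC1`: 46700 nM.
Compound 2, `COc1ccc(/C=N/NC(=S)NC(C)(C)[C@H]2CC=C(C)CC2)cc1`: 37700 nM.
Compound 3, `CC1=CC[C@H](C(C)(C)NC(=S)N/N=C/c2cccc([N+](=O)[O-])c2)CC1`: > 100000 nM, a limit of the assay rather than a number.

Compound 2 holds the lower of the two numbers reported, but its gap to compound 1 lies within the usual scatter of repeated measurements, so the two cannot be told apart on these data. For compound 3 only the limit of > 100000 nM in this assay, at which 1 of the 3 values shown sits, is known. All that can be said is that this thiosemicarbazone series, with its shared core, sits in the weak range of growth inhibition.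

The untested member is compound 4, `CC1=CC[C@H](C(C)(C)NC(=S)N/N=C/c2ccc[nH]2)CC1`. It differs from compound 2 by the change (1H-pyrrol-2-yl in place of 4-methoxyphenyl on a carbon with a double bond to nitrogen), that is, 1H-pyrrol-2-yl in place of 4-methoxyphenyl on a carbon with a double bond to nitrogen. Going by the values given here, no measured pair in the set isolates a change of this kind, so there is nothing to set the size of the step against. Given that compounds 1 and 2 fall within the scatter of each other and compound 3 reaches a limit, no step beyond the scatter is expected in this assay for compound 4, in either direction. Compound 4 is therefore estimated at 45000 nM, with a range from 15000 nM to 120000 nM, which corresponds to an expected step of a 1.2-fold higher number from compound 2 to compound 4 (0.08 log units; within the scatter).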

Compound 4, concentration for total growth inhibition: 11500 nM
For compound 4 the middle estimate is 3.9-fold (0.59 log units) above the measured one, and the stated range ends above it.
By their numbers in this assay, from the lowest: compound 4; then compounds 2 and 1 (each within the scatter of the next). At a limit, above all of these: compound 3.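

Set on the carbon with a double bond to nitrogen, 1H-pyrrol-2-yl in place of 4-methoxyphenyl gives in this assay the first readable step in this series: a 3.3-fold lower number from compound 2 to compound 4 (0.52 log units; beyond the scatter), a modest change but one that shows this position can move the read-out. Compound 4 also separates from the unelaborated core, with a 4.1-fold lower number from compound 1 to compound 4 (0.61 log units; beyond the scatter), whereas compound 2 stayed within the scatter of compound 1, so among these compounds the identity of the ring counts, and not merely the presence of one. No step to compound 3 can be read, and its value is a limit rather than a number: the limit of > 100000 nM in this assay, at which 1 of the 4 values shown sits.

The change alters ring size, the hetero atom and the hydrogen-bond donors and acceptors all at once, and the compounds shown do not separate these features from one another. Going by these compounds, how a furan-2-yl, a thiophen-2-yl or a 1-methyl-1H-pyrrol-2-yl group at this place would compare with 1H-pyrrol-2-yl remains open.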